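Methoxy added to a chalcone amide: cytotoxicity on Vero cells

The source may report more compounds than this note shows. Statements on the series, on what has been measured and on what is new or still open speak of the compounds shown alone.

Measured compounds:
compound 1, `COC(=O)c1cc(-c2cccc(NC(=O)c3ccc(/C=C/C(=O)c4ccccc4)cc3)c2)on1`: > 50 ug/mL
compound 2, `CC(C)Cc1ccc(C(=O)/C=C/c2ccc(C(=O)O)cc2)cc1`: < 10 ug/mL

Of the compounds shown here, two have been tested in an ADME assay on Vero cells (Chlorocebus sabaeus) for cytotoxicity, read by MTT assay, with a stated time of 72 h; on this read-out lower numbers stand for higher toxicity in this test and higher numbers for lower toxicity in this test. Compound 1, `COC(=O)c1cc(-c2cccc(NC(=O)c3ccc(/C=C/C(=O)c4ccccc4)cc3)c2)on1`, gives > 50 ug/mL in this assay, and this value is a limit of the assay, not a number: compound 1 sits at the limit of > 50 ug/mL in this assay, at which 1 of the 2 values shown sits. Compound 2, `CC(C)Cc1ccc(C(=O)/C=C/c2ccc(C(=O)O)cc2)cc1`, gives < 10 ug/mL in this assay, which is also a limit, sitting at the limit of < 10 ug/mL in this assay, at which 1 of the 2 values shown sits. Among the compounds with values here, no step between the two measured compounds is available, since they differ in more than one place; the two values show only that compound 1 stands at the less toxic end of what this assay reports and compound 2 at the more toxic end.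

Compound 3, `COC(=O)c1cc(-c2cccc(NC(=O)c3ccc(/C=C/C(=O)c4ccccc4OC)cc3)c2)on1`, is not yet measured. It differs from compound 1 by methoxy in place of hydrogen on an aromatic carbon. The change is small and adds no charge. With compound 1 already at the upper limit of this assay, the step from compound 1 to compound 3 is expected to be none beyond the scatter, and a number no higher from compound 1 to compound 3 (the limit leaves the size open) is the estimate for it. Compound 3 is thus expected to give about 50 ug/mL in this assay, within a range from 20 ug/mL to 100 ug/mL, most likely reported again as a limit.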

Compound 3, half-maximal cytotoxic concentration: > 40 ug/mL
Compound 3 ended at the assay's limit; the forecaster's own chance of this, stated with the estimate: 70%; the middle value does not contradict the limit.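

In this assay, within the data shown here, the results for compound 1 and compound 3 are both limits and not numbers, and no step between these two compounds can be read. The compounds shown leave open whether methoxy in place of hydrogen on an aromatic carbon changes the half-maximal cytotoxic concentration at all, and in which direction.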